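The compounds below may be only part of what the source reports. "The series", "measured", "known", "first", "only" and "open" are said of these compounds alone.

Going by the values given here, compound 1 `Cn1ccc(-c2ccccc2NCC2=NCCN2)n1` is the only member of this set with a number in an in vitro functional assay on cells (Fibroblast) for agonist activity at Alpha-1D adrenergic receptor (Homo sapiens) (a higher number here means that more compound is needed for the effect, a lower number that less compound is needed), where compound 1 gives 15.9 nM. Compound 2 `CCn1ccc(-c2ccccc2NCC2=NCCN2)n1` reaches only a limit of the assay, < 100000 nM. Compound 3 `Cc1ccc(-c2ccccc2NCC2=NCCN2)n1C` likewise reaches only a limit of the assay, < 100000 nM. The step that the limit leaves unreadable from compound 1 to compound 2 therefore cannot be read, and the limit of < 100000 nM in this assay, at which 2 of the 3 values shown sit, is all that these two values convey. Compound 4 `Cn1ccnc1-c1ccccc1NCC1=NCCN1` differs from compound 1 by 1-methyl-1H-imidazol-2-yl in place of 1-methyl-1H-pyrazol-3-yl on an aromatic carbon. Among the compounds with values here, no measured step touches this exchange of one five-membered ring for another, so nothing in the set fixes its size or direction. The expected step of a 3.1-fold higher number from compound 1 to compound 4 (0.50 log units; beyond the scatter) is taken as a modest loss. Compound 4 is estimated at 50 nM, with a range from 5 nM to 500 nM.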

Compound 4, half-maximal effective concentration: 200 nM
Compound 4: the middle estimate sits 4.0-fold (0.60 log units) below what was measured; the measured number falls inside the stated range.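

In this assay, going by these compounds alone, exchanging 1-methyl-1H-pyrazol-3-yl for 1-methyl-1H-imidazol-2-yl on this aromatic carbon gives a 13-fold higher number from compound 1 to compound 4 (1.10 log units; beyond the scatter), the first step in the set that can be read. Two groups with matching heavy atoms and matching donor and acceptor counts are therefore not interchangeable at this position, although compound 4 still gives a measured number. Nothing measured here accounts for the size of this step.

The steps to compound 2 and compound 3 cannot be read. As far as these compounds go, what an amine or a carboxylic acid would give in place of either five-membered ring stays open.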